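The compounds below may be only part of what the source reports. "The series", "measured", "known", "first", "only" and "open" are said of these compounds alone.

Measured so far in a functional assay on HEK293 cells for agonist activity at Neuronal acetylcholine receptor; alpha4/beta2 (Homo sapiens), read by FLIPR and calcium flux; on this read-out lower numbers stand for an effect already at smaller amounts and higher numbers for an effect only at larger amounts of compound:

- compound 1, `Clc1cncc(N2CCCNCCC2)c1`: 170 nM
- compound 2, `COc1cc(N2CCCNCC2)cnc1Cl`: 91.2 nM
- compound 3, `COc1ccc(N2CCCNCC2)cn1`: 11000 nM

Within this small set compound 3 gives the highest number in this assay. Among the compounds with values here, both other compounds sit well below it, and each of those gaps lies beyond the scatter, so compound 3 is the one member of the series that acts only at clearly larger amounts. Within the data shown here, no pair among the three differs in a single place, so no single-point step can be read off from the measured compounds; compound 1 and compound 2 differ from compound 3 in more than one respect at once, and their numbers show only that the shared core can reach far lower values.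

The next compound, compound 4, `CCSc1ccc(N2CCCNCC2)cn1`, departs from compound 3 in one place: ethylsulfanyl in place of methoxy on an aromatic carbon. Nothing measured here tells how this assay responds to such a change. Among the measured compounds shown here, with no comparable step available, the expectation for compound 4 is a modest change at most, a 1.2-fold lower number from compound 3 to compound 4 (0.09 log units; within the scatter), with no clear direction beyond the scatter. Compound 4 is therefore estimated at 9000 nM in this assay, within a range of 2500 nM to 32000 nM.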

Compound 4, half-maximal effective concentration: 4470 nM
For compound 4 the middle estimate is 2.0-fold (0.30 log units) above the measured one; the measured number falls inside the stated range.
By their numbers in this assay, from the lowest: compounds 2 and 1 (each within the scatter of the next); then compound 4; then compound 3.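

Ethylsulfanyl in place of methoxy gives the first single-place step of the series in this assay, and that step is a 2.5-fold lower number from compound 3 to compound 4 (0.39 log units; beyond the scatter). It shows that this position, on an aromatic carbon next to the ring nitrogen, responds to the identity of the group there, and that the exchange of a group of 2 heavy atoms for one of 3 does not raise the number in this read-out. No measurement on hand offers an explanation for the shift.

This single step changes the oxygen to sulfur and lengthens the chain together, so the contribution of each remains unresolved; ethoxy and methylsulfanyl at the same place would separate the two. Also open, on these data alone, is whether the trend continues with a longer chain such as propylsulfanyl, and how a quite different group there, such as an amine, would read in this assay.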